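The source may hold more compounds than are shown below. What is called first, only, known or untested is meant among the compounds shown, and "the series" means these compounds.

In a functional assay on ECa-109 cells (Homo sapiens) for antiproliferative activity, read by MTT assay, with a stated time of 72 h (on this read-out lower numbers stand for stronger inhibition and higher numbers for weaker inhibition), compound 1 `CCCSc1nc(N/N=C/c2cccnc2)c2nnn(Cc3ccccc3)c2n1` gives > 64000 nM, which is a limit of the assay and not a number. Compound 2 `CCCSc1nc(N/N=C/c2ccccc2)c2nnn(Cc3ccccc3)c2n1` gives > 64000 nM, and this too is only a limit. Compound 2 therefore has no exact value, and it stands with compound 1 at the limit of > 64000 nM in this assay, at which 2 of the 2 values shown sit. Going by the values given here, the only measured change so far is a step that the two limits leave unreadable from compound 1 to compound 2, so there is no step size to carry forward.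

Compound 3 `CCCSc1nc(N/N=C(\C)c2ccc(Br)cc2)c2nnn(Cc3ccccc3)c2n1` has not yet been measured. Its structure departs from that of compound 2 as follows: a group of 10 heavy atoms (8 carbon, 1 nitrogen, 1 bromine; one six-membered aromatic ring of carbon only) in place of a group of 8 heavy atoms (7 carbon, 1 nitrogen; one six-membered aromatic ring of carbon only), on a nitrogen on an aromatic ring. The entering group still has one six-membered aromatic ring of carbon only, but it also brings a bromine. Among the compounds with values here, no measured step tests a change of this kind, so the data give no firm direction. The expectation rests on compound 2, whose reading is the limit > 64000 nM. The expected change in this assay is an at least 1.2-fold lower number from compound 2 to compound 3 (0.10 log units; that floor lies within the scatter), and a result at the same limit would be unsurprising. For compound 3 the estimate is 50000 nM, with an expected range from 12000 nM to 100000 nM.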

Compound 3, half-maximal inhibitory concentration: 4670 nM
For compound 3 the middle estimate is 11-fold (1.03 log units) above the measured one; measured number below the stated range.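

In this assay, going by these compounds alone, compound 3 gives 4670 nM, the only exact number among the three compounds, so the group on a nitrogen on an aromatic ring now has a readable effect on this core. Exchanging that group gives an at least 13-fold lower number from compound 2 to compound 3 (1.13 log units; beyond the scatter), and exchanging the group that carries the pyridin-3-yl ring gives an at least 13-fold lower number from compound 1 to compound 3 (1.13 log units; beyond the scatter). The entering group keeps a six-membered aromatic ring of carbon only and adds one carbon and a bromine, which shows that a change in this one place can move a compound away from the value where the other two compounds remain, which is a limit and not a number: the limit of > 64000 nM in this assay, at which 2 of the 3 values shown sit.

The bromine and the extra carbon enter together, so the compounds shown cannot say which of them accounts for the step, or whether both are needed. They also leave open whether a chlorine, a methoxy group or an amine in the place of the bromine would give a similar number, and whether a longer chain on the sulfur would change the result.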